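Swapping the Hydroxy of Compound 2 for Fluoro

A few compounds are considered here, and "the series" means these few. Any claim that something is new, unique, unknown or untested is made for them only; others in the source may bear on it.

The measured compounds and their values:
- compound 1, `COc1ccc(/C=C2\CCC/C(=C\c3ccccc3)C2=O)cc1`: 31.4%
- compound 2, `O=C1/C(=C/c2ccccc2)CCC/C1=C\c1cccc(O)c1`: 65.1%
- compound 3, `O=C1/C(=C/c2ccccc2)CCC/C1=C\c1ccc(O)c(O)c1`: 90.7%

In an assay on isolated protein for inhibition of Alpha glucosidase (Homo sapiens), with stated times of 5 min and 15 min, tested at 50 uM (a higher number here means more inhibition at the concentration tested (going by the name of the read-out), a lower number less inhibition), compound 2 stands second of the three, with compound 3 higher and compound 1 lower, both gaps beyond the scatter.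

Compound 4, `O=C1/C(=C/c2ccccc2)CCC/C1=C\c1cccc(F)c1`, differs from compound 2 in one place: fluoro in place of hydroxy on an aromatic carbon. The unmeasured compound thus loses the hydroxy that compound 2 carries on an aromatic carbon and gains fluoro there instead.

Within the data shown here, one measured step bears on this. Adding a hydroxy on an aromatic carbon gave a number 25.6 percentage points higher from compound 2 to compound 3 (beyond the scatter), a modest rise. Going the other way, taking the hydroxy out of compound 2, should therefore cost something; compound 1, which also carries no free hydroxy, sits at 31.4%, in the same direction. A drop beyond the scatter is expected for compound 4 in this assay, with a number 30.1 percentage points lower from compound 2 to compound 4 (beyond the scatter) as the estimated step. For compound 4 the estimate is 35%, with a likely range from 15% to 55%.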

Compound 4, a percentage reported as inhibition, at one concentration (the size of the read-out at that concentration, not a potency): 39.8%
For compound 4 the middle estimate is 4.8 percentage points below the measured one; the range from low to high includes it.
By their numbers in this assay, from the lowest: compounds 1 and 4 (each within the scatter of the next); then compound 2; then compound 3.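

In this assay, changing 3-hydroxyphenyl to 3-fluorophenyl gives a number 25.3 percentage points lower from compound 2 to compound 4 (beyond the scatter). The earlier step showed only what adding a second hydroxy to the ring does, whereas this one shows that the read-out also responds when the single hydroxy already on the ring is exchanged at its own place. The hydroxy counts as one hydrogen-bond donor and one acceptor and fluoro as neither, but nothing measured here ties that difference to the drop.

From the compounds shown here alone, it remains open how an amine or a carboxylic acid at this same place would compare with hydroxy and fluoro. The compounds shown also leave open where a plain hydrogen at this place would fall, which would separate the effect of losing hydroxy from that of gaining fluoro.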